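From 4-methylphenyl to 3-methoxyphenyl on the amide side chain

The source may hold more compounds than are shown below. What is called first, only, known or untested is meant among the compounds shown, and "the series" means these compounds.

For the measured compounds named here, in a functional assay on L6 cells (Rattus norvegicus) for inhibition, read by scintillation counting, with a stated time of 3 h (on this read-out lower numbers stand for stronger inhibition and higher numbers for weaker inhibition), compound 1 (`Cc1ccc(CNC(=O)c2nc(-c3ccc(F)cc3)n(CC[C@@H](O)C[C@@H](O)CC(=O)O)c2C2CC2)cc1`) gives 178 nM as the lowest of the two numbers so far, and compound 2 (`COc1ccc(CNC(=O)c2nc(-c3ccc(F)cc3)n(CC[C@@H](O)C[C@@H](O)CC(=O)O)c2C2CC2)cc1`) gives 6400 nM on the same read-out. Compound 3 (`COc1cccc(CNC(=O)c2nc(-c3ccc(F)cc3)n(CC[C@@H](O)C[C@@H](O)CC(=O)O)c2C2CC2)c1`) is still unmeasured. Its difference from compound 1 is 3-methoxyphenyl in place of 4-methylphenyl on a saturated chain carbon bound to an amide-type nitrogen and amounts to 3-methoxyphenyl in place of 4-methylphenyl on a saturated chain carbon bound to an amide-type nitrogen.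

Going by the values given here, only one measured step bears on this change: a 36-fold higher number from compound 1 to compound 2 (1.56 log units; beyond the scatter) for methoxy in place of methyl on an aromatic carbon. That step is large and beyond the scatter, but it is a single pair. Among the compounds with values here, no measured compound carries the 3-methoxyphenyl group, so it guides the direction better than the size. A rise in this assay is therefore expected, probably smaller than the measured step, with wide uncertainty. The expected change is a 5.6-fold higher number from compound 1 to compound 3 (0.75 log units; beyond the scatter) on this reading. Compound 3 is estimated at 1000 nM with an expected range of 250 nM to 5000 nM in this assay.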

Compound 3, half-maximal inhibitory concentration: 538 nM
For compound 3 the middle estimate is 1.9-fold (0.27 log units) above the measured one; low and high end bracket the measured number.
By their numbers in this assay, from the lowest: compound 1; then compound 3; then compound 2.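

In this assay, the effect of a methoxy group on this benzyl amide depends strongly on where it sits, with a 12-fold lower number from compound 2 to compound 3 (1.08 log units; beyond the scatter) for 3-methoxyphenyl in place of 4-methoxyphenyl, so the large penalty seen earlier belongs to the 4-methoxyphenyl group and not to every methoxy-bearing phenyl. The 3-methoxyphenyl group still does not match 4-methylphenyl, with a 3.0-fold higher number from compound 1 to compound 3 (0.48 log units; beyond the scatter), which leaves compound 1 with the lowest number of the three and places compound 3 between the other two. Nothing available explains why the two methoxy isomers differ so widely in this assay.

As far as these compounds go, the change from compound 1 to compound 3 alters both the substituent and its place on the ring, and how a 3-methylphenyl group would read remains open, so the two contributions cannot yet be separated. An unsubstituted phenyl group as a reference and a 3-aminophenyl or 3-chlorophenyl group would show whether the tolerance seen for compound 3 extends beyond methoxy on the amide side chain.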